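Tetrahydronaphthyl imidazoles: amino substituent variation

This account rests on a few compounds, and the source may have more. Where it says the series, first, only, none or still open, it means among the compounds named here.

Compound 1 `CN(c1cccc2c1CCCC2c1c[nH]cn1)S(C)(=O)=O` is the reference point of this pair. In an assay on isolated protein for binding affinity to Alpha-1D adrenergic receptor (Rattus norvegicus), read by radioligand binding (on this read-out lower numbers stand for stronger inhibition and higher numbers for weaker inhibition), compound 1 gives 708 nM, the lowest of the two numbers seen so far. Compound 2 `O=C(Nc1cccc2c1CCCC2c1c[nH]cn1)C(F)(F)F` carries a ((trifluoromethyl)carbonyl)amino group in place of the methyl(methylsulfonyl)amino group; in this assay compound 2 gives 3310 nM. Among the compounds with values here, the only measured step, a 4.7-fold higher number from compound 1 to compound 2 (0.67 log units; beyond the scatter), therefore runs toward weaker binding when the methyl(methylsulfonyl)amino group is exchanged for a carbonyl-bearing amino group.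

Compound 3 `COC(=O)Nc1cccc2c1CCCC2c1c[nH]cn1` has not been measured. It differs from compound 1 as follows: (methoxycarbonyl)amino in place of methyl(methylsulfonyl)amino on an aromatic carbon. Within the data shown here, the step from compound 1 to compound 2 is the one comparison that bears on this change, since both compound 2 and compound 3 replace the same methyl(methylsulfonyl)amino group with a (...carbonyl)amino group carrying one hydrogen-bond donor. A weakening of similar but perhaps smaller size is expected, because a 4.7-fold higher number from compound 1 to compound 2 (0.67 log units; beyond the scatter) was modest rather than large and the (methoxycarbonyl)amino group of compound 3 is not the ((trifluoromethyl)carbonyl)amino group of compound 2.

For compound 3 the expected step is a 2.3-fold higher number from compound 1 to compound 3 (0.35 log units; beyond the scatter). In this assay compound 3 is estimated at 1600 nM, with a range of 500 nM to 5000 nM.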

Compound 3, inhibition constant: 3020 nM
Compound 3: the middle estimate sits 1.9-fold (0.28 log units) below what was measured; the range from low to high includes it.
By their numbers in this assay, from the lowest: compound 1; then compounds 3 and 2 (each within the scatter of the next).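

In this assay, a second replacement of the methyl(methylsulfonyl)amino group on this aromatic carbon gives a 4.3-fold higher number from compound 1 to compound 3 (0.63 log units; beyond the scatter) and so shows that the weakening is not confined to the ((trifluoromethyl)carbonyl)amino group of compound 2. Across the two carbonyl-bearing groups, methoxy in place of trifluoromethyl on the carbonyl carbon gives a 1.1-fold lower number from compound 2 to compound 3 (0.04 log units; within the scatter) and so does not separate the two compounds, which places the readable difference in this set between the methyl(methylsulfonyl)amino group of compound 1 and the two carbonyl-bearing amino groups, with no compound shown going against it. No measurement at hand accounts for this difference.

The entering groups differ from the methyl(methylsulfonyl)amino group both in the methyl on the nitrogen and in the carbonyl that stands where the sulfonyl stood, so the two changes cannot be told apart here. A (methylsulfonyl)amino group without that methyl, or a methyl(methoxycarbonyl)amino group, would separate them, while a plain amine or a longer chain on the carbonyl would show how far the level shared by compound 2 and compound 3 extends.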